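This account rests on a few compounds, and the source may have more. Where it says the series, first, only, none or still open, it means among the compounds named here.

For the measured compounds named here, in an assay for inhibition of Pro-cathepsin H (Homo sapiens), read by fluorescence, tested at 50 uM (on this read-out lower numbers stand for less inhibition and higher numbers for more inhibition at the one concentration tested (going by the name of the read-out)), only one of the three compounds made so far has a number: compound 1 `OCCc1ccccc1Nc1nc(Cl)nc(Cl)n1` gives -11%. Going by the values given here, compound 2 `O=c1nc(SCc2ccccc2)nc(SCc2ccccc2F)[nH]1` shares its core with compound 3 `O=c1nc(SCc2ccccc2)nc(SCc2ccccc2[N+](=O)[O-])[nH]1`; in this assay compound 2 is recorded as "not determined" (no result reported), and compound 3 is recorded as "not determined" (no result reported), so compound 2 stands without a number at all, and the one other compound on the same core stands the same way. Compound 4 `O=c1nc(SCc2ccccc2)nc(SCC2CCCC2)[nH]1` is the new member of this series and is yet to be measured in this assay.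

The change from compound 2 to compound 4 is cyclopentyl in place of 2-fluorophenyl on a saturated chain carbon bound to a sulfur. Among the compounds with values here, no measured pair in this set shows what such a swap does in this assay, and with no number for compound 2 there is nothing to step from; the step in this assay can only be guessed, and nothing here points to a shift beyond the scatter in either direction.

Within the data shown here, the only anchor is compound 1, which gives -11% in this assay. Compound 4 is therefore expected to show about 0%, with an estimated range from -20% to 20%.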

Compound 4, a percentage reported as inhibition, at one concentration (the size of the read-out at that concentration, not a potency): 10.6%
Compound 4: middle estimate off by 10.6 percentage points, on the low side, within the range that was stated.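

In this assay, for the compounds shown here, compound 4 gives 10.6% but compound 2 has no number, so no step from 2-fluorophenyl to cyclopentyl can be read. These compounds leave open what that swap does to inhibition on the shared core. No supporting data bear on this result.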